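The compounds below may be only part of what the source reports. "The series", "measured", "known", "first", "only" and "open" are said of these compounds alone.

Measured so far in a functional assay (aorta) with Oryctolagus cuniculus as the target; a lower number here means a stronger inhibitor, a higher number a weaker inhibitor:
compound 1 `COCCO/C(O)=C1\C(C)=NC(C)=C(C(=O)OCCCN2C(=O)c3ccccc3S2(=O)=O)C1c1cccc([N+](=O)[O-])c1` gives 6.8 nM;
compound 2 `CCO/C(O)=C1\C(C)=NC(C)=C(C(=O)OCCCN2C(=O)c3ccccc3S2(=O)=O)C1c1ccccc1C(F)(F)F` gives 0.8 nM;
compound 3 `CC1=NC(C)=C(C(=O)OCCCN2C(=O)c3ccccc3S2(=O)=O)C(c2ccccc2C(F)(F)F)/C1=C(\O)OC(C)C` gives 2.7 nM.

Compound 3 thus stands second highest of the three, with compound 1 higher and compound 2 lower, both gaps beyond the scatter. Compound 4 `COCCO/C(O)=C1\C(C)=NC(C)=C(C(=O)OCCCN2C(=O)c3ccccc3S2(=O)=O)C1c1ccccc1C(F)(F)F` differs from compound 3 by 2-methoxyethyl in place of isopropyl on an oxygen on an unsaturated carbon. Among the measured compounds shown here, only one measured step touches this position: a 3.4-fold higher number from compound 2 to compound 3 (0.53 log units; beyond the scatter), where branching the ester chain raised the number. For the measured compounds named here, compound 4 removes that branching but adds a longer chain with an oxygen, which no measured step covers directly, and compound 1 carries the same 2-methoxyethyl group on a different core, so it gives no step here. Compound 4 is therefore estimated to come out with a 1.8-fold lower number from compound 3 to compound 4 (0.26 log units; within the scatter) in this assay, expected around 1.5 nM (range 0.5 nM to 5 nM).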

Compound 4, half-maximal inhibitory concentration: 1.4 nM
Compound 4: the middle estimate sits 1.1-fold (0.03 log units) above what was measured; the measured number falls inside the stated range.
By their numbers in this assay, from the lowest: compounds 2, 4 and 3 (each within the scatter of the next, the first and the last beyond it); then compound 1.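

In this assay, 2-methoxyethyl on this oxygen gives a 1.9-fold lower number from compound 3 to compound 4 (0.29 log units; within the scatter) and a 1.8-fold higher number from compound 2 to compound 4 (0.24 log units; within the scatter), so compound 4 cannot be separated from either, even though compound 2 and compound 3 differ beyond the scatter. With 2-methoxyethyl held constant, 2-(trifluoromethyl)phenyl in place of 3-nitrophenyl gives a clearer shift: a 4.9-fold lower number from compound 1 to compound 4 (0.69 log units; beyond the scatter). No available evidence explains these numbers. Still open, going by these compounds, is how an amine or a longer chain on this oxygen would compare.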